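A few compounds are considered here, and "the series" means these few. Any claim that something is new, unique, unknown or untested is made for them only; others in the source may bear on it.

Working notes on the ether-linked series around a shared core.

Three compounds have numbers in an ADME assay on Vero cells (Chlorocebus sabaeus) for cytotoxicity, read by luminescence, with a stated time of 2 days; on this read-out higher numbers stand for lower toxicity in this test and lower numbers for higher toxicity in this test. Compound 1 `CCc1nc2ccccc2n1CCCCOCc1ccccc1` gives 32 uM in this assay. Compound 2 `CCc1nc2ccc(OC)cc2n1CCCCOc1ccccc1` gives 27 uM, and compound 3 `CCc1nc2ccc(C)cc2n1CCCOc1ccc(C)c(C)c1` gives 7.3 uM. Compound 1 has the highest of the three numbers; the gap to compound 2 lies within the scatter, so the two are read as equivalent, while the gap to compound 3 lies beyond the scatter. No pair of these compounds differs in only one place, so no single-change step can be read from the measured set.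

Compound 4 `CCc1nc2ccccc2n1CCCCOc1ccncc1` is not yet measured. It differs from compound 1 in one place: pyridin-4-yl in place of benzyl on an oxygen on a saturated carbon. Nothing measured here isolates an exchange of this kind, so the expectation rests on the position of compound 1 alone, and the step is expected to stay within the scatter, with no preferred direction. The step from compound 1 to compound 4 in this assay is thus estimated as a 1.0-fold higher number from compound 1 to compound 4 (0.01 log units; within the scatter). For compound 4 the expected value in this assay is 33 uM, with a range from 15 uM to 75 uM.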

Compound 4, half-maximal toxic concentration: > 50 uM
Compound 4 ended at the assay's limit (the forecaster's own chance of this, stated with the estimate: 20%); middle value at least 1.5-fold (0.18 log units) from the limit.
By their numbers in this assay, from the lowest: compound 3; then compounds 2 and 1 (each within the scatter of the next). At a limit, above all of these: compound 4.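

Compound 4 reads > 50 uM in this assay, and this is a limit of the assay, not a number. Among these compounds, this is the first single-change step, and pyridin-4-yl in place of benzyl on an oxygen on a saturated carbon is read as an at least 1.5-fold higher number from compound 1 to compound 4 (0.19 log units; that floor lies within the scatter), so at this place the exchange brings no sign of a lower number, although the floor of the step alone does not separate the two compounds. How far the step really reaches cannot be read, because the reading of compound 4 stops at the limit: the limit of > 50 uM in this assay, at which 1 of the 4 values shown sits.

The exchange alters two things at once, the ring gaining a nitrogen and the saturated carbon on the oxygen being lost, and the compounds shown do not tell these apart, since none on the core of compound 1 carries phenyl or pyridin-3-yl on that oxygen. Also open, on these data alone, is whether the step holds on the substituted cores of compound 2 and compound 3, or with a shorter chain or an amine at the same place.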